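Propyl-to-fluoro swap on the cinnamamide phenyl

The source may report more compounds than this note shows. Statements on the series, on what has been measured and on what is new or still open speak of the compounds shown alone.

Measured so far:
- compound 1, `CCCc1ccc(/C=C/C(=O)Nc2ccc3nc(CCC)cc(N)c3c2)cc1`: 4 nM
- compound 2, `CCCc1cc(NC2CCC2)c2cc(NC(=O)/C=C/c3ccc(C(F)(F)F)cc3)ccc2n1`: 18 nM

Compound 1 holds the lowest number of the two in an assay on isolated protein for displacement of a labelled ligand from melanin-concentrating hormone receptor 1 (Homo sapiens); on this read-out lower numbers stand for stronger inhibition and higher numbers for weaker inhibition; the nearest is compound 2, whose number is higher by a margin beyond the scatter. Compound 2 differs from compound 1 in more than one place, so its value can only be set beside that of compound 1, not read as a single step.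

Compound 3, `CCCc1cc(N)c2cc(NC(=O)/C=C/c3ccc(F)cc3)ccc2n1`, is not yet measured. It differs from compound 1 by fluoro in place of propyl on an aromatic carbon, on a six-membered aromatic ring of carbon only, para to a large group. For the measured compounds named here, no step between measured compounds covers this change. Going by the values given here, a loss is expected: compound 3 is estimated to sit beyond the scatter above compound 1, with a 3.8-fold higher number from compound 1 to compound 3 (0.57 log units; beyond the scatter), because compound 2 gives 18 nM and is the only other compound without propyl at this position. The expected value for compound 3 in this assay is 15 nM, within a range of 4 nM to 60 nM.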

Compound 3, half-maximal inhibitory concentration: 130 nM
For compound 3 the middle estimate is 8.7-fold (0.94 log units) below the measured one; the whole stated range lies below it.
By their numbers in this assay, from the lowest: compound 1; then compound 2; then compound 3.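

In this assay, for the compounds shown here, the only single change read so far at this position, fluoro in place of propyl on an aromatic carbon, gives a 33-fold higher number from compound 1 to compound 3 (1.51 log units; beyond the scatter) and so puts a large size on a change at this site, with the rest of the structure held constant. The position is therefore far from indifferent to its substituent, even though the groups differ by only two heavy atoms and neither carries a hydrogen-bond donor or acceptor. Nothing measured here accounts for the size of this step, so the swap alone cannot show whether the loss follows from removing the propyl chain or from introducing fluoro.

Still open, on these data alone, is whether an ethyl or butyl chain, a methoxy group or a chlorine atom at this position would stay near compound 1 or fall toward compound 3, which would separate the effect of chain length from that of the fluorine atom. The trifluoromethyl group of compound 2 gives no further reading, as compound 2 differs from both other compounds in more than one place and its steps cannot be read.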